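This account rests on a few compounds, and the source may have more. Where it says the series, first, only, none or still open, it means among the compounds named here.

Measured in a functional assay on HT cells (Homo sapiens) for antiproliferative activity, read by fluorescence, with a stated time of 72 h; a lower number here means a stronger inhibitor of growth, a higher number a weaker inhibitor of growth:
- compound 1 `CC(C)c1n[nH]c2c(NCc3ccc(-c4ccccn4)cc3)nc(SCC(C)(C)N)nc12`: 85 nM
- compound 2 `CC(C)c1n[nH]c2c(NCc3ccc(-c4ccccn4)cc3)nc(SCCC(N)=O)nc12`: 120 nM

In this assay, among the compounds with values here, compound 2 at 120 nM lies within the scatter of the only other measured compound, so neither can be ranked above the other. Next in the series is compound 3 `CC(C)c1n[nH]c2c(NCc3ccc(-c4ccccn4)cc3)nc(SCCn3ccnc3)nc12`. The structural difference is 1H-imidazol-1-yl in place of carbamoyl on a saturated chain carbon, two bonds along the chain from a sulfur.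

Within the data shown here, one measured step bears on this change: a 1.4-fold higher number from compound 1 to compound 2 (0.15 log units; within the scatter). That step also altered the group carried on the chain bound to the sulfur, and it stayed within the scatter. Among the measured compounds shown here, this is thin evidence, since it is a single step and no measured compound carries a ring on this chain. On that basis, no clear direction is expected, and no step beyond the scatter. The expected step is a 1.2-fold lower number from compound 2 to compound 3 (0.08 log units; within the scatter). The estimate for compound 3 is 100 nM, with an expected range of 35 nM to 300 nM.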

Compound 3, concentration for 50% growth inhibition: 155 nM
For compound 3 the middle estimate is 1.6-fold (0.19 log units) below the measured one, and the stated range covers the measured number.
By their numbers in this assay, from the lowest: compounds 1, 2 and 3 (each within the scatter of the next).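

In this assay the chain on the sulfur now carries a ring, and 1H-imidazol-1-yl in place of carbamoyl, on a saturated chain carbon, two bonds along the chain from a sulfur, gives a 1.3-fold higher number from compound 2 to compound 3 (0.11 log units; within the scatter) even though the entering group has 0 hydrogen-bond donors where carbamoyl has 1. Against compound 1, (1H-imidazol-1-yl)methyl in place of 1-amino-1-methylethyl gives a 1.8-fold higher number from compound 1 to compound 3 (0.26 log units; within the scatter) and so the three groups seen at this place, an amine, a carbamoyl and a five-membered aromatic ring with 2 hetero atoms, cannot be ranked in this assay. No measurement in hand explains these numbers or says what this position does with the groups placed on it.

Still open, from the compounds shown here alone, is whether a carboxylic acid, a phenyl ring or a longer chain between the sulfur and the end group would give a step beyond the scatter. Also open, going by these compounds, is whether a 1,2,4-triazol-1-yl ring in place of 1H-imidazol-1-yl would read the same as compound 3.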